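Fluorine Added to the Least Stable Compound

This account rests on a few compounds, and the source may have more. Where it says the series, first, only, none or still open, it means among the compounds named here.

Compound 1 `C[C@H](Nc1nc(N)nc(N)c1C#N)c1cc2ccc(F)cn2c(=O)c1-c1ccccc1` in an ADME assay on microsomes from liver (Mus musculus), read by LC-MS, using NADPH, with a stated time of 30 min, tested at 1 uM (a higher number here means that more of the compound is left, a lower number that less of the compound is left), gives 42%. Compound 2 `C[C@H](Nc1nc(N)nc(N)c1C#N)c1cc(=O)n2cc(F)ccc2c1-c1ccc(F)cc1` has no number in this assay: "not determined" (no result reported). Among the measured compounds shown here, compound 3 `C[C@H](Nc1nc(N)nc(N)c1C#N)c1c(-c2ccccc2)c(=O)n2cc(F)ccc2c1-c1ccccc1` gives 13%, the lowest of the two numbers known here; the only measured step, a number 29 percentage points lower from compound 1 to compound 3 (beyond the scatter), carries a phenyl in place of a hydrogen. Compound 4 `C[C@H](Nc1nc(N)nc(N)c1C#N)c1c(-c2ccccc2)c(=O)n2cc(F)ccc2c1-c1ccc(F)cc1` differs from compound 3 by fluoro in place of hydrogen on an aromatic carbon. No measured step carries this same change, and compound 2, which would have shown it against compound 1, has no number, so nothing here says which way it goes. The step expected in this assay is therefore one within the scatter: no change at the digits printed from compound 3 to compound 4 (within the scatter). Compound 4 is estimated at 13%, with a range from 4% to 28%.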

Compound 4, percent of the compound remaining in the Mus musculus assay: 83%
Compound 4: the middle estimate sits 70 percentage points below what was measured, and the stated range ends below it.
By their numbers in the Mus musculus assay, from the lowest: compound 3; then compound 1; then compound 4.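

In the Mus musculus assay compound 3 gives 13% and compound 4 gives 83%; one fluoro atom on the phenyl ring, para to a large group, gives a number 70 percentage points higher from compound 3 to compound 4 (beyond the scatter) and so shows that this position responds strongly to a one-atom change. In the Mus musculus assay phenyl gives a number 29 percentage points lower from compound 1 to compound 3 (beyond the scatter) while 4-fluorophenyl in the same place gives a number 41 percentage points higher from compound 1 to compound 4 (beyond the scatter) and so reverses the direction. In a physicochemical assay for solubility (a lower number here means a less soluble compound, a higher number a more soluble compound), compound 3 gives 50600 nM and compound 4 gives 68500 nM, and the same fluoro change gives a 1.4-fold higher number from compound 3 to compound 4 (0.13 log units; within the scatter) and so does not separate the two compounds.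

On these data alone, whether chloro or a methoxy group here would act like fluoro stays open, and compound 2 has no number to show the fluoro change without the added ring. No measurement shown gives a reason for the rise.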